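The source may hold more compounds than are shown below. What is called first, only, known or untested is meant among the compounds shown, and "the series" means these compounds.

Measured in a functional assay on SV5A8 cells (Homo sapiens) for cytotoxicity; a lower number here means a stronger inhibitor, a higher number a weaker inhibitor:
- compound 1, `Cc1ccc2c(NCc3ccc(NC(=O)C4CCN(Cc5ccc(F)cc5)CC4)cc3)nc(N(C)C)nc2c1`: > 4820 nM
- compound 2, `Cc1ccc2c(NCc3ccc(NC(=O)C4CCN(Cc5ccccc5)CC4)cc3)nc(N3CCC3)nc2c1`: > 8500 nM

Compound 1 gives only a limit in this assay, > 4820 nM, so its true potency is not pinned to a number. Compound 2 also sits at a limit, > 8500 nM. With both values being limits, neither compound can be ranked against the other.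

Compound 3, `Cc1ccc2c(NCc3ccc(NC(=O)C4CCN(Cc5ccc(Cl)cc5)CC4)cc3)nc(N(C)C)nc2c1`, differs from compound 1 by chloro in place of fluoro on an aromatic carbon. Among the compounds with values here, no measured pair isolates this change, so no step beyond the usual scatter is expected, and compound 3 will most likely again fall at a limit. Compound 3 is estimated at 7000 nM, between 2500 nM and 25000 nM, an expected step that the limit leaves unreadable from compound 1 to compound 3.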

Compound 3, half-maximal inhibitory concentration: > 3180 nM
Compound 3 ended at the assay's limit; the forecaster's own chance of this, stated with the estimate: 80%; the middle value lies beyond the limit too.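

Compound 1 and compound 3 both end at limits in this assay, and the step between them cannot be read. The compounds shown leave open the true potency of each, and whether fluoro and chloro differ at all.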